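The source may report more compounds than this note shows. Statements on the series, on what has been measured and on what is new or still open speak of the compounds shown alone.

Compound 2 `O=C(/C=C/c1cc2ccccc2[nH]c1=O)c1ccc(O)cc1` gives 3980 nM in a functional assay on SK-MEL-5 cells (Homo sapiens) for cytotoxicity, read by sulforhodamine B assay, with a stated time of 24 h (a lower number here means a stronger inhibitor of growth, a higher number a weaker inhibitor of growth), and stands alongside compound 1 `COc1ccc(C(=O)/C=C/c2cc3ccccc3[nH]c2=O)cc1`, which gives 5730 nM; the two lie within the scatter of each other, as the step of a 1.4-fold lower number from compound 1 to compound 2 (0.16 log units; within the scatter) shows. Compound 3 `O=C(/C=C/c1cc2ccccc2[nH]c1=O)c1ccc(Cl)cc1` differs from compound 2 by chloro in place of hydroxy on an aromatic carbon, on an aromatic carbon of a six-membered aromatic ring of carbon only, para to a large group; cut one bond further out, the change reads 4-hydroxyphenyl to 4-chlorophenyl. Among the compounds with values here, only the step from compound 1 to compound 2 bears on this position, and it stayed within the scatter, so nothing measured here points to a large move in this assay in either direction. The step from hydroxy to chloro is therefore expected to be small, a 1.1-fold lower number from compound 2 to compound 3 (0.06 log units; within the scatter). The estimate for compound 3 is 3500 nM, with a range from 1200 nM to 10000 nM.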

Compound 3, concentration for 50% growth inhibition: 18900 nM
Compound 3: middle estimate off by 5.4-fold (0.73 log units), on the low side, and the stated range ends below it.
By their numbers in this assay, from the lowest: compounds 2 and 1 (each within the scatter of the next); then compound 3.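

On this aromatic carbon, para to a large group, the choice of group does make a difference in this assay: chloro in place of hydroxy gives a 4.7-fold higher number from compound 2 to compound 3 (0.68 log units; beyond the scatter), and chloro in place of methoxy gives a 3.3-fold higher number from compound 1 to compound 3 (0.52 log units; beyond the scatter), both beyond the scatter. Within the data shown here, the earlier pair showed only that hydroxy and methoxy, both joined to the ring through oxygen, lie within the scatter of each other, whereas chloro, joined through no oxygen, is the first group here to stand apart from them. Nothing measured alongside these numbers accounts for the weaker growth inhibition seen with chloro.

On these data alone, whether this shift belongs to chloro alone or extends to other groups without oxygen remains open. An amine, a carboxylic acid or a fluoro group on the same carbon would show how far it reaches.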